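The compounds below may be only part of what the source reports. "The series", "measured", "known", "first", "only" and "open" are said of these compounds alone.

In a functional assay on NPC-TW01 cells (Homo sapiens) for inhibition, read by MTT assay, with a stated time of 72 h (a lower number here means a stronger inhibitor of growth, a higher number a weaker inhibitor of growth), compound 1, whose structure is `Cc1ccc(-c2cc(N)n(-c3ccc(Br)cc3)n2)cc1`, gives 80200 nM. Compound 2, `Nc1cc(-c2ccc(Cl)cc2)nn1-c1ccc(Br)cc1`, differs from it by chloro in place of methyl on an aromatic carbon and gives 64400 nM in this assay. That change made a 1.2-fold lower number from compound 1 to compound 2 (0.10 log units; within the scatter).

Compound 3, `Cc1ccc(-c2cc(/N=C/N(C)C)n(-c3ccc(Br)cc3)n2)cc1`, carries a larger group where compound 1 carries a small one: the difference is a group of 5 heavy atoms (3 carbon, 2 nitrogen; no ring) in place of one nitrogen atom, on an aromatic carbon. For compound 3 this assay reports only a limit, > 100000 nM, and not a number. That reading for compound 3 is the limit of > 100000 nM in this assay, at which 1 of the 3 values shown sits. The step from this change is an at least 1.2-fold higher number from compound 1 to compound 3 (0.09 log units; that floor lies within the scatter).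

Compound 4, `CN(C)/C=N/c1cc(-c2ccc(Cl)cc2)nn1-c1ccc(Br)cc1`, has not yet been measured in this assay. It differs from compound 3 by chloro in place of methyl on an aromatic carbon, which is the same change that was made from compound 1 to compound 2, at the same place on the ring, while the cores of the two pairs differ as described for compound 3 against compound 1.

Compound 4 is expected to show a step that the limit leaves unreadable from compound 3 to compound 4, because the same change once gave a 1.2-fold lower number from compound 1 to compound 2 (0.10 log units; within the scatter) in compound 2, a step that sits within the usual scatter. Since compound 3 already sits at the limit, compound 4 is expected to come out near 110000 nM, most likely between 55000 nM and 250000 nM, and quite possibly again only as a limit.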

Compound 4, concentration for 50% growth inhibition: 60700 nM
For compound 4 the middle estimate is 1.8-fold (0.26 log units) above the measured one; measured number inside the range.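

In this assay compound 3 stands only as a limit of > 100000 nM and not as a number, so the change from 4-methylphenyl to 4-chlorophenyl on this core can be read only as a floor, an at least 1.6-fold lower number from compound 3 to compound 4 (0.21 log units; that floor lies within the scatter). That floor does not show that the swap of methyl for chloro alters growth inhibition on this core, nor does it show that the swap carries over unchanged from one core to the other: the same change on two cores in this assay, a 1.2-fold lower number (0.10 log units; within the scatter) from compound 1 to compound 2 and an at least 1.6-fold lower number (0.21 log units; that floor lies within the scatter) from compound 3 to compound 4; the limit leaves it open whether they differ. The larger group in place of one nitrogen atom, read on the chloro pair, gives a 1.1-fold lower number from compound 2 to compound 4 (0.03 log units; within the scatter), so that pair cannot be told apart, but this result cannot be carried over to the methyl pair either: the same change on two cores in this assay, an at least 1.2-fold higher number (0.09 log units; that floor lies within the scatter) from compound 1 to compound 3 and a 1.1-fold lower number (0.03 log units; within the scatter) from compound 2 to compound 4; the limit leaves it open whether they differ.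

A true number for compound 3 would be needed before the two steps of either change could be compared. The compounds shown also leave open what happens with other groups in place of the methyl or chloro, such as fluoro, methoxy or a nitrile, or with a carboxylic acid or a longer chain in place of the larger group.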